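The source may hold more compounds than are shown below. What is called first, only, known or untested is meant among the compounds shown, and "the series" means these compounds.

The measured compounds:
compound 1, `N#CC1=C(N)Oc2c(c3nc4ccccc4nc3c3ccccc23)C12C(=O)N(Cc1cnnn1-c1ccc(Cl)cc1)c1ccccc12`: > 50000 nM
compound 2, `N#CC1=C(N)Oc2c(c3nc4ccccc4nc3c3ccccc23)C12C(=O)N(Cc1cnnn1-c1ccccc1Cl)c1ccccc12`: 42600 nM
compound 3, `CCOc1ccc(-n2nncc2CN2C(=O)C3(C(C#N)=C(N)Oc4c3c3nc5ccccc5nc3c3ccccc43)c3ccccc32)cc1`: 25200 nM

In a functional assay on A549 cells (Homo sapiens) for antiproliferative activity, read by MTT assay, with a stated time of 48 h (on this read-out higher numbers stand for weaker inhibition and lower numbers for stronger inhibition), compound 1 stands at > 50000 nM, which is a limit of the assay and not a number, (the limit of > 50000 nM in this assay, at which 1 of the 3 values shown sits). Compound 2 gives 42600 nM in this assay, and compound 3 gives 25200 nM. The step of an at least 1.1-fold lower number from compound 1 to compound 2 (0.06 log units; that floor lies within the scatter) and the step of an at least 1.9-fold lower number from compound 1 to compound 3 (0.29 log units; that floor lies within the scatter) both start from the limit, and the step of a 1.7-fold lower number from compound 2 to compound 3 (0.23 log units; within the scatter) lies within the scatter, so all three compounds sit at the weak end of what this assay resolves.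

Compound 4, `Cc1ccc(C)c(-n2nncc2CN2C(=O)C3(C(C#N)=C(N)Oc4c3c3nc5ccccc5nc3c3ccccc43)c3ccccc32)c1`, differs from compound 1 by 2,5-dimethylphenyl in place of 4-chlorophenyl on an aromatic nitrogen. The nearest measured steps are those that also exchange the group on the aromatic nitrogen: the change to 2-chlorophenyl and to 4-ethoxyphenyl each left the number weak, with no step beyond the scatter among them. On that basis the step of an at least 1.2-fold lower number from compound 1 to compound 4 (0.09 log units; that floor lies within the scatter) is expected to be small, with the number for compound 4 expected near the limit, possibly again reported only as a limit. Compound 4 is therefore estimated at 40000 nM in this assay, within 15000 nM to 100000 nM.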

Compound 4, half-maximal inhibitory concentration: > 50000 nM
Compound 4 gave a limit, no number (the forecaster's own chance of this, stated with the estimate: 40%); middle value at least 1.2-fold (0.09 log units) away from the limit.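

Compound 4, which carries 2,5-dimethylphenyl on the aromatic nitrogen, gives > 50000 nM in this assay, a limit and not a number, and compound 1 stands at that same limit: the limit of > 50000 nM in this assay, at which 2 of the 4 values shown sit.

The step between these two compounds cannot be read, so the exchange of 4-chlorophenyl for 2,5-dimethylphenyl has no measurable size. The two readable steps, an at least 1.9-fold higher number from compound 3 to compound 4 (0.29 log units; that floor lies within the scatter) and an at least 1.1-fold higher number from compound 2 to compound 4 (0.06 log units; that floor lies within the scatter), have floors within the scatter, so a phenyl ring with two methyl groups, the first carbon-only substitution seen at this position, adds no step beyond the scatter to those seen with the chloro and ethoxy groups.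

The compounds shown leave open whether a group of another kind on this aromatic nitrogen, such as a phenyl ring bearing an amine or a carboxylic acid, or a longer alkyl chain in place of the ring, would give a clearly lower number in this assay. They also leave open whether this position can move the number at all, with all four compounds at the weak end of the assay.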